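The compounds below may be only part of what the source reports. "The series", "measured", "known", "first", "only" and "open" are said of these compounds alone.

Measured compounds:

Compound 1 `C=CCn1c(=O)/c(=C\c2cccc(Cl)c2)[nH]c(=O)/c1=C\c1ccccc1OC`: 4500 nM
Compound 2 `C=CCn1c(=O)/c(=C\c2cc(Br)ccc2F)[nH]c(=O)/c1=C\c1ccccc1OC`: 17400 nM
Compound 3 `C=CCn1c(=O)/c(=C\c2ccccc2OC)[nH]c(=O)/c1=C\c1ccccc1OC`: 15700 nM

In a functional assay on HL-60 cells (Homo sapiens) for cytotoxicity, read by CCK-8 assay, with a stated time of 72 h (a lower number here means a stronger inhibitor, a higher number a weaker inhibitor), compound 3 holds the second highest of the three numbers. Its nearest neighbour is compound 2, and the step of a 1.1-fold lower number from compound 2 to compound 3 (0.04 log units; within the scatter) lies within the scatter, so the two cannot be ordered. Its furthest neighbour is compound 1, and the step of a 3.5-fold higher number from compound 1 to compound 3 (0.54 log units; beyond the scatter) is beyond the scatter, so compound 3 is the weaker of that pair.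

Compound 4 `C=CCn1c(=O)/c(=C\c2ccc(C)cc2)[nH]c(=O)/c1=C\c1ccccc1OC` differs from compound 3 in one place: 4-methylphenyl in place of 2-methoxyphenyl on a double-bonded chain carbon bound to an aromatic carbon. Going by the values given here, no measured step puts a 4-methylphenyl at this position, so only indirect evidence bears on the change. The two steps that involve the 2-methoxyphenyl, a 3.5-fold higher number from compound 1 to compound 3 (0.54 log units; beyond the scatter) and a 1.1-fold lower number from compound 2 to compound 3 (0.04 log units; within the scatter), show that exchanging the aryl group at this position moves the number by a modest amount at most, in either direction or not at all. The step of a 3.9-fold higher number from compound 1 to compound 2 (0.59 log units; beyond the scatter) confirms this scale for a swap between two other aryl groups.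

The expected step in this assay, a 1.6-fold lower number from compound 3 to compound 4 (0.20 log units; within the scatter), is therefore modest and uncertain in direction. Compound 4 is estimated to give about 10000 nM, with a range from 3000 nM to 35000 nM.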

Compound 4, half-maximal inhibitory concentration: "not active" (no number reported)
Nothing numeric was reported for compound 4, so the estimate cannot be set against anything.
By their numbers in this assay, from the lowest: compound 1; then compounds 3 and 2 (each within the scatter of the next).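

In this assay, going by these compounds alone, compound 4 was reported as "not active" without a number, so no step between compound 4 and compound 3, or any other compound, can be read. On these data alone, how far 4-methylphenyl in place of 2-methoxyphenyl shifts the number remains open. No further measurement shown here bears on this result.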